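Replacing a Dichlorophenyl Group with a Methylsulfonylphenyl Group

This account rests on a few compounds, and the source may have more. Where it says the series, first, only, none or still open, it means among the compounds named here.

Three compounds built on a shared core have been examined in an assay for binding affinity to dual specificity mitogen-activated protein kinase kinase 4 (Homo sapiens), read by KINOMEscan, tested at 100 nM; on this read-out lower numbers stand for a stronger effect and higher numbers for a weaker effect at the one concentration tested. Compound 1 `CCCS(=O)(=O)Nc1ccc(F)c(C(=O)c2n[nH]c3ncc(-c4cccc(Cl)c4)cc23)c1F` gives 40%. Compound 2 `CCCS(=O)(=O)Nc1ccc(F)c(C(=O)c2n[nH]c3ncc(-c4cccc(C)c4)cc23)c1F` gives 15%, and compound 3 `CCCS(=O)(=O)Nc1ccc(F)c(C(=O)c2n[nH]c3ncc(-c4ccc(Cl)c(Cl)c4)cc23)c1F` gives 45%. Compound 3 carries the highest number of the three, although its separation from compound 1 is small: a number 5 percentage points higher from compound 1 to compound 3 (within the scatter). Its separation from compound 2 is larger: a number 30 percentage points higher from compound 2 to compound 3 (beyond the scatter). The step of a number 25 percentage points lower from compound 1 to compound 2 (beyond the scatter) points the same way, so among these three the methyl-bearing compound 2 sits apart from the two chloro-bearing compounds.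

Compound 4 `CCCS(=O)(=O)Nc1ccc(F)c(C(=O)c2n[nH]c3ncc(-c4ccc(S(C)(=O)=O)cc4)cc23)c1F` has not yet been measured. It differs from compound 3 in one place: 4-(methylsulfonyl)phenyl in place of 3,4-dichlorophenyl on an aromatic carbon. Going by the values given here, none of the measured steps brings in a methylsulfonyl group, so the only guidance is that the exchange of chloro for methyl moved the number modestly, while adding a second chloro changed little. The new group is unlike both, so the direction of the step in this assay is open and the uncertainty is wide. Compound 4 is therefore expected to give about 45%, with a range from 15% to 85%. The expected step is no change at the digits printed from compound 3 to compound 4 (within the scatter).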

Compound 4, a percentage reported as activity, at one concentration (the size of the read-out at that concentration, not a potency): 1.5%
Beside the measured number, compound 4's estimate is 43.5 percentage points above it; the whole stated range lies above it.
By their numbers in this assay, from the lowest: compound 4; then compound 2; then compounds 1 and 3 (each within the scatter of the next).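

Going by these compounds alone, the aryl group at this position of the shared core can move the read-out in this assay much further than the earlier compounds showed: the 4-(methylsulfonyl)phenyl group gives a number 43.5 percentage points lower from compound 3 to compound 4 (beyond the scatter) and a number 38.5 percentage points lower from compound 1 to compound 4 (beyond the scatter), both printed as large, where the steps among the first three compounds were modest or lay within the scatter. It also carries the series past its previous lowest number, with a number 13.5 percentage points lower from compound 2 to compound 4 (beyond the scatter), so the methyl of compound 2 no longer marks the low end, and a group with 2 hydrogen-bond acceptors gives a lower number here than the aryl groups with 0 that it replaces. No measurement shown here accounts for the size of this step, so its origin remains unexplained.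

The compounds shown cannot separate the contribution of the methylsulfonyl group from that of losing the chloro or methyl substituents, and a plain phenyl or a phenyl bearing a sulfonamide or a carboxylic acid would help to tell these apart. All the numbers also come from one concentration in this assay, so they leave the potency of compound 4 open, as well as its behaviour at any other kinase.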